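Epimer at the ring carbon: compound 2 against compound 4

The source may hold more compounds than are shown below. What is called first, only, known or untested is meant among the compounds shown, and "the series" means these compounds.

The series is read in a functional assay on KB cells (Homo sapiens) for cytotoxicity; on this read-out higher numbers stand for an effect only at larger amounts of compound and lower numbers for an effect already at smaller amounts. Compound 1 `CCCCCCC(=O)C(Br)=C(Br)Br` is an open-chain tribromo ketone. In this assay compound 1 gives only a limit, > 20 ug/mL. Compound 3 `CCCCC1=C(Br)/C(=C/Br)OC1=O` is a brominated lactone with an exocyclic bromomethylene. In this assay compound 3 likewise gives only a limit, > 20 ug/mL. Among the compounds with values here, compound 2 `CCC[C@@H](OC(C)=O)C1=C(Br)[C@@](OC)(C(Br)Br)OC1=O` carries an acetoxy-bearing butyl side chain on a brominated lactone whose saturated ring carbon bears a methoxy and a dibromomethyl group; in this assay compound 2 gives 3.9 ug/mL, the only finite number in the set, the other two entries sitting at the limit of > 20 ug/mL in this assay, at which 2 of the 3 values shown sit. Within the data shown here, no pair of measured compounds differs in a single place, so no measured step is available.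

Compound 4 `CCC[C@@H](OC(C)=O)C1=C(Br)[C@](OC)(C(Br)Br)OC1=O` differs from compound 2 as follows: the two compounds have the same atoms and bonds and differ only in configuration as drawn: 1 of 2 stereo elements differ; a stereocentre at a saturated ring carbon is drawn S in compound 2 and R in compound 4. Among the measured compounds shown here, with no measured step of this kind, no direction can be read from the data; the expectation is a step within the scatter, with a real chance that the value moves either way. On that basis compound 4 is expected to come out at 5 ug/mL, with a range from 1.5 ug/mL to 15 ug/mL, which means an expected step of a 1.3-fold higher number from compound 2 to compound 4 (0.11 log units; within the scatter).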

Compound 4, concentration for half-maximal effect: 5.3 ug/mL
Compound 4: middle estimate off by 1.1-fold (0.03 log units), on the low side, and the stated range covers the measured number.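

Within the data shown here, the first measured step falls on the stereocentre at a saturated ring carbon: in this assay, going from S to R gives a 1.4-fold higher number from compound 2 to compound 4 (0.13 log units; within the scatter). On this read-out, the configuration at this carbon therefore does not separate the two epimers, and this single pair shows that either drawn configuration at this position can give a finite value in this assay. The reading of this step concerns configuration alone, with no other structural change involved: the fact that compounds 2 and 4 differ only in the configuration as drawn

The compounds shown leave open how the second stereo element, which is the same in compound 2 and compound 4, bears on the read-out, since no step changes it. Among these compounds, they also leave open what the acetoxy, methoxy and dibromomethyl groups each contribute, as no single-place step touches them, so a free hydroxyl in place of the acetoxy, or a longer chain in place of the butyl side chain, would be the kind of change needed to give this position its first substituent reading.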